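A Longer Hydroxyl Arm on a Silent Macrocycle

A few compounds are considered here, and "the series" means these few. Any claim that something is new, unique, unknown or untested is made for them only; others in the source may bear on it.

Compound 1 `N#Cc1ncc2nc1OCC/C=C\COc1ccc(O)cc1NC(=O)N2` stands only as a limit in a functional assay on NCI-H1299 cells (Homo sapiens), read by flow cytometry; on this read-out lower numbers stand for an effect already at smaller amounts and higher numbers for an effect only at larger amounts of compound: compound 1 gives > 10000 nM, a limit of the assay rather than a number. Compound 2 `N#Cc1ncc2nc1OCC/C=C\COc1ccc(Cl)cc1NC(=O)N2` likewise gives > 10000 nM, a limit. Compound 3 `Cc1ccc2c(c1)NC(=O)Nc1cnc(C#N)c(n1)OCC/C=C\CO2` gives > 10000 nM, again a limit. Compound 4 `N#Cc1ncc2nc1OCC/C=C\COc1ccc(CCO)cc1NC(=O)N2` differs from compound 1 by 2-hydroxyethyl in place of hydroxy on an aromatic carbon. The measured steps a step that the two limits leave unreadable from compound 1 to compound 2, a step that the two limits leave unreadable from compound 1 to compound 3 and a step that the two limits leave unreadable from compound 2 to compound 3 all concern substituents on an aromatic carbon of the shared core, yet none is readable in size because of the limit of > 10000 nM in this assay, at which 3 of the 3 values shown sit. Nothing measured therefore points to a step in either direction beyond the scatter. Compound 4 is thus expected to remain at the limit, with an estimated step that the limit leaves unreadable from compound 1 to compound 4. The estimate for compound 4 is 15000 nM, ranging from 5000 nM to 50000 nM.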

Compound 4, half-maximal effective concentration: > 10000 nM
Compound 4: only a limit was reported (the forecaster's own chance of this, stated with the estimate: 85%); the middle value lies beyond the limit too.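

For the compounds shown here, no step from compound 1, compound 2 or compound 3 to compound 4 can be read, because all of them stand at the same limit: the limit of > 10000 nM in this assay, at which 4 of the 4 values shown sit. The compounds shown leave open whether any substituent at this place on the shared core gives a measurable value in this assay.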